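Fluoro to bromo on compound 2

The source may hold more compounds than are shown below. What is called first, only, known or untested is meant among the compounds shown, and "the series" means these compounds.

- Compound 1 `Nc1cccn2cc(Cc3ccc(F)cc3)c(=O)nc12`: 135000 nM
- Compound 2 `O=c1nc2ccccn2cc1Cc1ccc(F)cc1`: 200000 nM

Among the compounds with values here, in a functional assay on MCF7 cells (Homo sapiens) for cytotoxicity, read by MTT assay, with a stated time of 24 h (a higher number here means a weaker inhibitor, a lower number a stronger inhibitor), compound 2 stands level with its only measured neighbour, and the numbers give the pair no order. Compound 3 `O=c1nc2ccccn2cc1Cc1ccc(Br)cc1` differs from compound 2 by bromo in place of fluoro on an aromatic carbon, para to a large group. Within the data shown here, the only measured step, a 1.5-fold higher number from compound 1 to compound 2 (0.17 log units; within the scatter), concerns amino rather than this halogen, and no measured step covers the change itself. With so little to go on, no shift beyond the scatter is expected. The expected change is a 1.3-fold lower number from compound 2 to compound 3 (0.12 log units; within the scatter). Compound 3 is estimated at 150000 nM, with an expected range of 70000 nM to 300000 nM.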

Compound 3, half-maximal inhibitory concentration: 157000 nM
Estimate against measurement, compound 3: 1.0-fold (0.02 log units) below; low and high end bracket the measured number.
By their numbers in this assay, from the lowest: compounds 1, 3 and 2 (each within the scatter of the next).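

In this assay the aromatic carbon para to a large group now has its first measured step, with bromo in place of fluoro (a 1.3-fold lower number from compound 2 to compound 3 (0.11 log units; within the scatter)). Between these two halogens the position shows no change beyond the scatter, whereas the earlier pair spoke only to amino on the core. No available evidence bears on this result.

As far as these compounds go, whether a group other than a halogen at this carbon, such as an amine, a carboxylic acid or a longer chain, would move the number remains open.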